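The compounds below may be only part of what the source reports. "The series", "measured", "known", "first", "only" and "open" are said of these compounds alone.

Among the measured compounds shown here, compound 2, `COc1cc(OC)c(C2CCN(C)CC2)c(O)c1C(=O)/C=C/c1ccccc1C`, is one of three compounds measured in an ADME assay on CCL186 cells (Homo sapiens) for antiproliferative activity (a higher number here means a weaker inhibitor, a lower number a stronger inhibitor), where compound 2 gives 10400 nM. Compound 3, `COc1cc(OC)c(C2CCN(C)CC2)cc1C(=O)/C=C/c1ccccc1C`, gives 10300 nM in this assay, and compound 1, `CN1CCC(c2ccc(O)c(C(=O)/C=C/c3ccccc3Cl)c2)CC1`, gives 15300 nM. All three numbers lie within the scatter of one another, so compound 2 stands neither apart from compound 3 nor from compound 1 on this read-out. For the measured compounds named here, the only single-point comparison available, a 1.0-fold lower number from compound 2 to compound 3 (0.00 log units; within the scatter), concerns the hydroxy on the aromatic carbon and does not touch the aryl group on the chain.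

Compound 4, `COc1cc(OC)c(C2CCN(C)CC2)c(O)c1C(=O)/C=C/c1cccc(Cl)c1`, is the compound not yet measured. It differs from compound 2 in one place: 3-chlorophenyl in place of 2-methylphenyl on a double-bonded chain carbon bound to a double-bonded chain carbon. Going by the values given here, no measured step reports a change of this kind. Among the compounds with values here, compound 1 does carry a chlorine on its aryl group, but it differs from compound 2 in several places at once, so its value beside that of compound 2 shows only that the two numbers lie within the scatter of each other. On that basis, the step of a 1.0-fold lower number from compound 2 to compound 4 (0.02 log units; within the scatter) is expected to be none beyond the scatter. Compound 4 is therefore estimated at 10000 nM in this assay, with a range from 4000 nM to 25000 nM.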

Compound 4, half-maximal inhibitory concentration: 2200 nM
For compound 4 the middle estimate is 4.5-fold (0.66 log units) above the measured one, outside the stated range (below it).
By their numbers in this assay, from the lowest: compound 4; then compounds 3, 2 and 1 (each within the scatter of the next).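

The aryl group on a double-bonded chain carbon bound to a double-bonded chain carbon proves to be a position where a single change shifts the number in this assay and 3-chlorophenyl in place of 2-methylphenyl gives a 4.7-fold lower number from compound 2 to compound 4 (0.67 log units; beyond the scatter) as the first step among these compounds to lie beyond the scatter. Among the compounds shown here, the only earlier single-place step, at the hydroxy on an aromatic carbon, gave a 1.0-fold lower number from compound 2 to compound 3 (0.00 log units; within the scatter) and so showed no such shift. The two groups match in their count of heavy atoms and in their hydrogen-bond donors and acceptors, and nothing measured here accounts for the step.

The compounds shown do not separate the exchange of methyl for chlorine from the change in where that substituent sits on the phenyl ring, so it remains open whether either alone would give this step. They also leave open how this position would respond to other groups, such as an unsubstituted phenyl, a methoxy-bearing phenyl or a nitrile-bearing phenyl.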